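The source may report more compounds than this note shows. Statements on the series, on what has been measured and on what is new or still open speak of the compounds shown alone.

Working notes on the series. Three analogues share the core of compound 1, `CCOC(=O)C1=C(Nc2ccccc2)S/C(=C\c2ccc(O)c(O)c2)C1=O`, and have been measured in a functional assay on JAR cells (Homo sapiens) for inhibition, read by MTT assay, with a stated time of 72 h, tested at 10 uM; a higher number here means more inhibition at the concentration tested (going by the name of the read-out), a lower number less inhibition. Compound 1 gives 48.7%. Compound 2, `CCOC(=O)C1=C(Nc2ccc(OC)c(OC)c2)S/C(=C\c2ccc[nH]2)C1=O`, gives 47.9% in this assay, and compound 3, `CCOC(=O)C1=C(Nc2cccc([N+](=O)[O-])c2)S/C(=C\c2ccc[nH]2)C1=O`, gives 57.4%. On the raw numbers compound 1 stands second of the three, with compound 2 nearest to it and compound 3 furthest away, but all three figures lie within the usual scatter of one another, so none of the three can be set apart from the others.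

Compound 4, `CCOC(=O)C1=C(Nc2ccccc2)S/C(=C\c2cccnc2)C1=O`, has not yet been measured. It differs from compound 1 in one place: pyridin-3-yl in place of 3,4-dihydroxyphenyl on a double-bonded chain carbon bound to a double-bonded ring carbon. Among the compounds with values here, no pair among the measured compounds shows this same change, and the measured compounds differ from one another in more than one place, so there is no measured step to lean on.

With nothing to anchor the change, the expected step is a number 4.7 percentage points lower from compound 1 to compound 4 (within the scatter), small enough to stay within the scatter, leaning if anything toward slightly less inhibition. Compound 4 is therefore estimated at 44% in this assay, with a range from 24% to 64%.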

Compound 4, a percentage reported as inhibition, at one concentration (the size of the read-out at that concentration, not a potency): 32.1%
Beside the measured number, compound 4's estimate is 11.9 percentage points above it, within the range that was stated.
By their numbers in this assay, from the lowest: compound 4; then compounds 2, 1 and 3 (each within the scatter of the next).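

Within the data shown here, the exchange of 3,4-dihydroxyphenyl for pyridin-3-yl on a double-bonded chain carbon bound to a double-bonded ring carbon is the first change that can be read on its own, and in this assay it gives a number 16.6 percentage points lower from compound 1 to compound 4 (beyond the scatter) with the rest of compound 1 unchanged. Among these compounds, this shows that the position is not indifferent to the group it carries, which the earlier compounds could not show, since they differ from one another in more than one place and their numbers lie within the scatter. The exchange alters the ring atoms, the heavy-atom count and the hydrogen-bond donors and acceptors all at once, and no supporting measurement separates these or explains the step.

Going by these compounds, whether the step follows from losing the hydroxyl groups or from bringing in the ring nitrogen stays open, and a plain phenyl or a phenyl with a single hydroxyl at this position would help to separate the two. Also open, on these data alone, is whether a step of this size holds when the rest of the core carries other groups, such as the nitro group of compound 3.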